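The compounds below may be only part of what the source reports. "The series", "measured", "known", "first", "only" and "open" are said of these compounds alone.

Measured so far in a functional assay on MDA-MB-231 cells (Homo sapiens) for antiproliferative activity, read by MTT assay, with a stated time of 48 h; on this read-out higher numbers stand for weaker inhibition and lower numbers for stronger inhibition:
compound 1 `COc1ccc(N(C)c2cc(C)nc(C)n2)cc1` gives 3650 nM
compound 2 `COc1ccc(N(C)c2cc(C)nc(C)n2)cc1F` gives 2790 nM
compound 3 `COc1ccc(N(C)c2cc(C)nc(C)n2)cc1O` gives 1100 nM

Compound 1 and compound 2 are not separated, since the data show only a 1.3-fold lower number from compound 1 to compound 2 (0.12 log units; within the scatter) and no more. Compound 3 stands apart from both, with a 3.3-fold lower number from compound 1 to compound 3 (0.52 log units; beyond the scatter) and a 2.5-fold lower number from compound 2 to compound 3 (0.40 log units; beyond the scatter) in the same direction, which leaves compound 1 at the weak end alongside compound 2.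

Compound 4 `C[Se]c1ccc(N(C)c2cc(C)nc(C)n2)cc1` keeps the core of compound 1 and changes one group: a group of 2 heavy atoms (1 carbon, 1 selenium; no ring) in place of a group of 2 heavy atoms (1 carbon, 1 oxygen; no ring), on an aromatic carbon on an aromatic carbon, para to a large group. All three measured steps leave the methoxy group in place, so none speaks directly to this swap. Within the data shown here, they show only that single changes on this series have stayed modest, the largest being a 3.3-fold lower number from compound 1 to compound 3 (0.52 log units; beyond the scatter) in this small set.

No large move is therefore expected in this assay, and the estimated step is a 1.8-fold lower number from compound 1 to compound 4 (0.26 log units; within the scatter) with its direction uncertain. For compound 4 the expected value is 2000 nM with an estimated range from 600 nM to 7000 nM.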

Compound 4, half-maximal inhibitory concentration: 321 nM
Compound 4: middle estimate off by 6.2-fold (0.79 log units), on the high side; measured number below the stated range.
By their numbers in this assay, from the lowest: compound 4; then compound 3; then compounds 2 and 1 (each within the scatter of the next).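

In this assay, among these compounds, the methoxy group on the aromatic carbon para to a large group turns out to be a sensitive point, as the group of 1 carbon and 1 selenium that replaces it gives an 11-fold lower number from compound 1 to compound 4 (1.06 log units; beyond the scatter) and so the only step in this set printed as large. The earlier changes left the methoxy group in place, so they could not show this. Both groups have 2 heavy atoms, so this large step comes with no change in that count, and nothing here explains the effect of the exchange.

The compounds shown leave open whether selenium itself is needed, which a methylthio group in the same place would help to test. They also leave open how a longer chain on the selenium would read, and whether adding a fluoro or hydroxy group to compound 4 would shift its value further.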